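This account rests on a few compounds, and the source may have more. Where it says the series, first, only, none or still open, it means among the compounds named here.

The compounds measured so far in a functional assay with platelet-activating factor receptor (Cavia porcellus) as the target; on this read-out lower numbers stand for an effect already at smaller amounts and higher numbers for an effect only at larger amounts of compound:

compound 1 `COc1cccc(C(=C/C=C/C(=O)NCCCCc2cccnc2)c2cccc(OC)c2)c1`, 0.36 mg/kg
compound 2 `CC/C(=C\C=C\C(=O)N[C@H](C)CCCc1cccnc1)c1ccc(OC)cc1`, 0.68 mg/kg
compound 3 `CCC/C(=C\C=C\C(=O)N[C@H](C)CCCc1cccnc1)c1ccc(OC)cc1`, 0.52 mg/kg

Compound 4 `COc1cccc(C(=C/C=C/C(=O)N[C@H](C)CCCc2cccnc2)c2cccc(OC)c2)c1` has not yet been measured in this assay. It differs from compound 1 in one place: methyl in place of hydrogen on a saturated chain carbon bound to an amide-type nitrogen and a saturated chain carbon. The same kind of change occurs once more among these compounds, from compound 2 to compound 3: methyl in place of hydrogen on a saturated chain carbon, two bonds along the chain from a double-bonded chain carbon. The places are not the same: in that pair the methyl enters on a saturated chain carbon two bonds along the chain from a double-bonded chain carbon, whereas in compound 4 it enters on a saturated chain carbon bound to an amide-type nitrogen and a saturated chain carbon. That measured step was a 1.3-fold lower number from compound 2 to compound 3 (0.12 log units; within the scatter). How the core of compound 1 differs from that of compound 2 is not broken down here. Compounds 2 and 3 already carry the methyl that enters in compound 4, and their values in this assay lie close to that of compound 1. Among the compounds with values here, since the one measured step of this kind, a 1.3-fold lower number from compound 2 to compound 3 (0.12 log units; within the scatter), stayed within the scatter, compound 4 is expected to sit near compound 1, with an expected step of a 1.1-fold higher number from compound 1 to compound 4 (0.05 log units; within the scatter). The estimate for compound 4 in this assay is 0.4 mg/kg, expected to fall between 0.15 mg/kg and 1 mg/kg.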

Compound 4, dose for 50% inhibition: 0.21 mg/kg
The estimate for compound 4 lay 1.9-fold (0.28 log units) above the measured number; the measured number falls inside the stated range.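

In this assay, methyl in place of hydrogen on a saturated chain carbon bound to an amide-type nitrogen and a saturated chain carbon gives a 1.7-fold lower number from compound 1 to compound 4 (0.23 log units; within the scatter), and the two steps of this kind read alike: the same change on two cores in this assay, a 1.3-fold lower number (0.12 log units; within the scatter) from compound 2 to compound 3 and a 1.7-fold lower number (0.23 log units; within the scatter) from compound 1 to compound 4, 1.3-fold (0.12 log units) apart, within the scatter of two such steps
Neither step lies beyond the scatter, so neither core shows a clear effect of the methyl. This does not show that the change carries over at one place, for in the earlier pair the methyl enters on a saturated chain carbon two bonds along the chain from a double-bonded chain carbon, and two pairs cannot speak for other cores.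

Open, on these data alone, is whether an ethyl or a longer chain on the carbon bound to the amide-type nitrogen would also stay within the scatter in this assay. As far as these compounds go, a carboxylic acid there remains equally open.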